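The compounds below may be only part of what the source reports. "The series", "measured", "known", "first", "only" and "open" are said of these compounds alone.

In a functional assay on PC-3 cells (Homo sapiens) for cytotoxicity, read by MTT assay, with stated times of 48 h and 4 h (on this read-out higher numbers stand for weaker inhibition and lower numbers for stronger inhibition), compound 1 (`CCN(CC)CCNc1nc(/C=C/c2ccc(OC)c(OC)c2)nc2ccccc12`) gives 50300 nM and compound 2 (`COc1ccc(/C=C/c2nc(NCCN3CCCCC3)c3ccccc3n2)cc1OC`) gives 78500 nM. Compound 2 therefore stands within the scatter of compound 1, and the two cannot be ranked. Within the data shown here, the only measured step, a 1.6-fold higher number from compound 1 to compound 2 (0.19 log units; within the scatter), exchanges diethylamino for piperidin-1-yl and leaves the 3,4-dimethoxyphenyl group unchanged. Compound 3 (`O=[N+]([O-])c1ccc(/C=C/c2nc(NCCN3CCCCC3)c3ccccc3n2)cc1`) retains the piperidin-1-yl group of compound 2 but changes the aromatic group: 4-nitrophenyl in place of 3,4-dimethoxyphenyl on a double-bonded chain carbon bound to a double-bonded chain carbon. Among the measured compounds shown here, no measured step covers this exchange, so the data give no direction for it and only a weak guide to its size. No shift beyond the scatter is therefore expected in this assay, though the uncertainty is wide. The expected change is a 1.4-fold lower number from compound 2 to compound 3 (0.15 log units; within the scatter). For compound 3 the estimate is 55000 nM, with an expected range of 18000 nM to 120000 nM.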

Compound 3, half-maximal inhibitory concentration: 25600 nM
For compound 3 the middle estimate is 2.1-fold (0.33 log units) above the measured one; the range from low to high includes it.
By their numbers in this assay, from the lowest: compounds 3, 1 and 2 (each within the scatter of the next, the first and the last beyond it).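

In this assay the group on a double-bonded chain carbon bound to a double-bonded chain carbon proves able to shift the number: 4-nitrophenyl in place of 3,4-dimethoxyphenyl gives a 3.1-fold lower number from compound 2 to compound 3 (0.49 log units; beyond the scatter) and lies beyond the scatter, though the step is modest. The earlier exchange of diethylamino for piperidin-1-yl, a 1.6-fold higher number from compound 1 to compound 2 (0.19 log units; within the scatter) and within the scatter, gave no such reading at its own position. Nothing at hand accounts for the step at the aromatic group.

Open, going by these compounds, is whether the step belongs to the entering nitro group or to the loss of the two methoxy groups, which a plain phenyl or a 4-methoxyphenyl group at this position would separate. Also open, on these data alone, is whether the step holds with diethylamino or with a longer chain to the piperidine.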